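The source may hold more compounds than are shown below. What is called first, only, known or untested is meant among the compounds shown, and "the series" means these compounds.

Measured so far:
compound 1 `CCC[C@@H](N)C(=O)NCc1ccccc1`, 35 mg/kg
compound 2 `C=CCOCC(N)C(=O)NCc1ccccc1`, 75 mg/kg

Both numbers come from a functional assay on the whole organism (strain NMRI) for inhibition, with Mus musculus as the target, in the formalin test, with a stated time of 30 min; on this read-out higher numbers stand for an effect only at larger amounts of compound and lower numbers for an effect already at smaller amounts. On the numbers shown, compound 2 gives the highest value of the two; its nearest neighbour is compound 1, whose number is lower by a gap beyond the scatter. Compound 3 `CCC(C)C(N)C(=O)NCc1ccccc1` is not yet measured in this assay. It differs from compound 2 as follows: sec-butyl in place of (allyloxy)methyl on a saturated chain carbon bound to an amine nitrogen and a carbonyl carbon. Going by the values given here, no measured step covers this change. Because compound 1, which also carries no oxygen on the saturated chain carbon bound to an amine nitrogen and a carbonyl carbon, gives 35 mg/kg, a downward step beyond the scatter is expected, a 1.9-fold lower number from compound 2 to compound 3 (0.27 log units; within the scatter). For compound 3 a value near 40 mg/kg is estimated, within 20 mg/kg to 80 mg/kg.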

Compound 3, dose for half-maximal effect: > 22 mg/kg
Compound 3 was reported as a limit (the forecaster's own chance of this, stated with the estimate: 5%); the middle value does not contradict the limit.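

Compound 3 gives > 22 mg/kg, a limit and not a number. The step from compound 2 to compound 3 cannot be read. Still open, as far as these compounds go, is how sec-butyl compares with (allyloxy)methyl on the saturated chain carbon bound to an amine nitrogen and a carbonyl carbon.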